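Solubility notes: from compound 2 to compound 3

The source may report more compounds than this note shows. Statements on the series, on what has been measured and on what is new or still open speak of the compounds shown alone.

Values in a physicochemical assay for solubility, in phosphate buffer, at pH 7.4 (a lower number here means a less soluble compound, a higher number a more soluble compound), stand as follows
- compound 1 `CCOC(=O)c1c(-c2ccc(Cl)cc2)[nH]c2cccc(OC)c2c1=O` gives > 100000 nM (a limit of the assay, not a number)
- compound 2 `CCOC(=O)c1c(-c2ccccc2Cl)[nH]c2cc(OC)ccc2c1=O` gives 28000 nM (a number)

For the measured compounds named here, compound 2 holds the only true number so far, and compound 1 stands at a limit. The counted difference 4-methoxyphenyl in place of 2-chlorophenyl on an aromatic carbon leads to compound 3 `CCOC(=O)c1c(-c2ccc(OC)cc2)[nH]c2cc(OC)ccc2c1=O` with 4-methoxyphenyl in place of 2-chlorophenyl on an aromatic carbon next to the ring nitrogen. Going by the values given here, no measured step covers this change. Nothing beyond the scatter is expected in this assay and the estimated step (a 1.1-fold lower number from compound 2 to compound 3 (0.05 log units; within the scatter)) has no firm direction. Compound 3 is estimated at 25000 nM (expected range 7000 nM to 90000 nM).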

Compound 3, solubility: 8000 nM
Beside the measured number, compound 3's estimate is 3.1-fold (0.49 log units) above it; the range from low to high includes it.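

At the aromatic carbon next to the ring nitrogen, 4-methoxyphenyl in place of 2-chlorophenyl gives a 3.5-fold lower number from compound 2 to compound 3 (0.54 log units; beyond the scatter) in this assay. For the compounds shown here, this is the only readable step, and it shows that the read-out responds to the aryl group at this position, though the step is modest. Nothing shown bears on the cause of this step.

On these data alone, both the chlorine and the methoxy group differ between these two compounds, so their separate contributions remain open. As far as these compounds go, whether an unsubstituted phenyl, a 4-carboxyphenyl or an aminomethyl-bearing phenyl would follow the same direction also remains open.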